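The compounds below may be only part of what the source reports. "The series", "measured", "known", "first", "only" and "open" are said of these compounds alone.

Measured so far in a functional assay on A549 cells (Homo sapiens) for antiproliferative activity, read by MTT assay, with a stated time of 48 h; on this read-out higher numbers stand for weaker inhibition and lower numbers for stronger inhibition:
- compound 1, `CCc1ccc(OCc2cn(-c3cc(=O)oc4ccc(Br)cc34)nn2)cc1`, gives 11600 nM
- compound 2, `O=c1cc(-n2cc(COc3ccc(Br)cc3)nn2)c2cc(Br)ccc2o1`, gives 24500 nM

Among the compounds with values here, compound 2 stands highest of the two numbers so far; its nearest neighbour is compound 1, and the step of a 2.1-fold higher number from compound 1 to compound 2 (0.32 log units; beyond the scatter) came with bromo in place of ethyl on an aromatic carbon, a modest change beyond the scatter.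

Compound 3, `COC(=O)c1ccc(OCc2cn(-c3cc(=O)oc4ccc(Br)cc34)nn2)cc1`, differs from compound 2 by methoxycarbonyl in place of bromo on an aromatic carbon. Within the data shown here, no measured step concerns a methoxycarbonyl group; the only step available, a 2.1-fold higher number from compound 1 to compound 2 (0.32 log units; beyond the scatter), replaces a different group at the same place and shows that substitution at this position moves this assay by a modest amount. By analogy, a modest move is expected, direction uncertain, leaning slightly toward a lower number: the estimate is a 1.5-fold lower number from compound 2 to compound 3 (0.19 log units; within the scatter). Compound 3 is therefore expected to give 16000 nM in this assay, within a range of 6000 nM to 45000 nM.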

Compound 3, half-maximal inhibitory concentration: 660 nM
Beside the measured number, compound 3's estimate is 24-fold (1.38 log units) above it; measured number below the stated range.
By their numbers in this assay, from the lowest: compound 3; then compound 1; then compound 2.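

In this assay, the group on the aromatic carbon para to a large group can move the number much further than the earlier pair showed: the modest 2.1-fold higher number from compound 1 to compound 2 (0.32 log units; beyond the scatter) contrasts with the large 37-fold lower number from compound 2 to compound 3 (1.57 log units; beyond the scatter) and the large 18-fold lower number from compound 1 to compound 3 (1.24 log units; beyond the scatter) on replacing ethyl. Methoxycarbonyl therefore separates from both bromo and ethyl at this place, and compound 3 has the lowest number of the three, with both of its steps beyond the scatter. Nothing available accounts for this large shift.

Open, going by these compounds, is whether the shift needs the whole methoxycarbonyl group or would also appear with a carboxylic acid, a primary amide or an acetyl group at this place. Also open, on these data alone, is whether methoxycarbonyl elsewhere on this ring would give a comparable number.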